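This account rests on a few compounds, and the source may have more. Where it says the series, first, only, none or still open, it means among the compounds named here.

Measured compounds:
- Compound 1, `COc1ccc(C23CCC(=O)N2CCCO3)cc1`, in a functional assay on the whole organism (Central nervous system) for activation, with Mus musculus as the target; on this read-out lower numbers stand for an effect already at smaller amounts and higher numbers for an effect only at larger amounts of compound: < 150 mg/kg, a limit of the assay and not a number.
- Compound 2, `Cc1ccc(C23CCC(=O)N2CCCO3)c(C)c1`, in this assay: < 50 mg/kg, likewise a limit of the assay.

Going by the values given here, compound 1 therefore stands at the limit of < 150 mg/kg in this assay, at which 1 of the 2 values shown sits, while the limit of < 50 mg/kg in this assay, at which 1 of the 2 values shown sits, holds the only other value shown; neither entry is an exact number, so no step between the two measured compounds can be counted, and nothing can be said about which of them acts at the smaller dose.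

Compound 3, `O=C1CCC2(c3ccc(Cl)cc3)OCCCN12`, has not yet been measured in this assay. It differs from compound 1 in one place: chloro in place of methoxy on an aromatic carbon. Among the compounds with values here, with no measured step between related compounds to lean on, the expected change from compound 1 to compound 3 in this assay is taken as small, within the usual scatter or at most a modest shift in either direction, as a step that the limit leaves unreadable from compound 1 to compound 3 expresses. On that basis compound 3 is estimated to give about 75 mg/kg in this assay, with a range from 25 mg/kg to 200 mg/kg, and it is quite possible that the assay again reports only a limit.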

Compound 3, dose for half-maximal effect: 75 mg/kg
The estimate for compound 3 equals the measured number at the digits printed, and the stated range covers the measured number.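

In this assay compound 1 gives < 150 mg/kg, a limit of the assay and not a number. Going by these compounds alone, compound 3 gives 75 mg/kg, so no step from compound 1 to compound 3 can be read. The compounds shown leave open whether chloro in place of methoxy on an aromatic carbon changes the dose needed in this assay, and by how much.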